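Adding a nitro group to compound 1

A few compounds are considered here, and "the series" means these few. Any claim that something is new, unique, unknown or untested is made for them only; others in the source may bear on it.

In a functional assay on MIA PaCa-2 cells (Homo sapiens) for cytotoxicity, read by MTT assay, with a stated time of 72 h (on this read-out higher numbers stand for weaker inhibition and lower numbers for stronger inhibition), compound 1 (`COC1=CC(=O)c2c(c(COc3ccccc3)c(C)n2C)C1=O`) gives 962 nM and stands highest of the two measured numbers, with compound 2 (`COC1=CC(=O)c2c(c(COc3cccc([N+](=O)[O-])c3)c(C)n2C)C1=O`) at 258 nM lying lower. Compound 3 (`COC1=CC(=O)c2c(c(COc3ccccc3[N+](=O)[O-])c(C)n2C)C1=O`) carries nitro in place of hydrogen on an aromatic carbon as its change from compound 1: nitro in place of hydrogen on an aromatic carbon, ortho to a large group. For the measured compounds named here, the one measured step with this exchange is a 3.7-fold lower number from compound 1 to compound 2 (0.57 log units; beyond the scatter) with the nitro at a different place. Going by the values given here, a smaller step toward lower numbers is expected in this assay for compound 3, as no measurement yet covers this place. The expected change is a 2.1-fold lower number from compound 1 to compound 3 (0.33 log units; beyond the scatter) in this estimate. Compound 3 is estimated at 450 nM with a range of 150 nM to 1200 nM overall.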

Compound 3, half-maximal inhibitory concentration: 104 nM
The estimate for compound 3 lay 4.3-fold (0.64 log units) above the measured number, and the stated range ends above it.
By their numbers in this assay, from the lowest: compound 3; then compound 2; then compound 1.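

On the aromatic carbon ortho to a large group, nitro in place of hydrogen gives a 9.3-fold lower number from compound 1 to compound 3 (0.97 log units; beyond the scatter) in this assay and so lowers the number here as well. Compound 2, with the nitro at a different place, stands at 258 nM and compound 3 at 104 nM on this read-out, so among these compounds the number depends on where the nitro sits. Nothing at hand explains why this place gives the lower number.

The compounds shown leave open whether an amine or a nitrile at this same place would give a similar number. They also leave open how a nitro group at this place would fare on a longer chain.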